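Spiro amine swap on the benzyloxy benzamide core

The source may hold more compounds than are shown below. What is called first, only, known or untested is meant among the compounds shown, and "the series" means these compounds.

Compound 3 `CN1CC2(C1)CN(c1ccc(OCc3ccccc3)c(C(=O)Nc3ccnnc3)c1)C2` gives 25.1 nM in an assay on Sf9 cells for inhibition of Leucine-rich repeat serine/threonine-protein kinase 2 (Homo sapiens), read by TR-FRET, with stated times of 30 min and 2 h; a lower number here means a stronger inhibitor, a higher number a weaker inhibitor. Among the three compounds with numbers, compound 3 holds the highest one, yet every step to it lies within the scatter: compound 1 `O=C(Nc1ccnnc1)c1cc(N2CCCC2)ccc1OCc1ccccc1` gives 20 nM in this assay, and compound 2 `C[C@@H]1CN(c2ccc(OCc3ccccc3)c(C(=O)Nc3ccnnc3)c2)C[C@H](C)O1` gives 20 nM. The steps of a 1.3-fold higher number from compound 1 to compound 3 (0.10 log units; within the scatter) and a 1.3-fold higher number from compound 2 to compound 3 (0.10 log units; within the scatter) are small, as is no change at the digits printed from compound 1 to compound 2 (within the scatter). Each of these steps alters only the amine on the same aromatic carbon, and none moves the number beyond the scatter.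

Compound 4 `CN1CC2(CCN(c3ccc(OCc4ccccc4)c(C(=O)Nc4ccnnc4)c3)CC2)C1` carries the next change at that position: a group of 10 heavy atoms (8 carbon, 2 nitrogen; one four-membered non-aromatic ring with 1 hetero atom, one six-membered non-aromatic ring with 1 hetero atom) in place of a group of 8 heavy atoms (6 carbon, 2 nitrogen; 2 four-membered non-aromatic rings with 1 hetero atom each), on an aromatic carbon. The three measured steps are the ones that bear on it, all varying the group on that aromatic carbon, and all three stayed within the scatter. In this assay the expected step is therefore a 1.0-fold lower number from compound 3 to compound 4 (0.00 log units; within the scatter), that is, none beyond the scatter. Compound 4 is accordingly estimated at 25 nM, with a range from 10 nM to 63 nM.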

Compound 4, half-maximal inhibitory concentration: 63.1 nM
Compound 4: middle estimate off by 2.5-fold (0.40 log units), on the low side; the measured number lies above the stated range.
By their numbers in this assay, from the lowest: compounds 1, 2 and 3 (each within the scatter of the next); then compound 4.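

Compound 4 shows that this aromatic carbon is not indifferent to every amine in this assay. Its group moves the number beyond the scatter against each earlier compound (a 2.5-fold higher number from compound 3 to compound 4 (0.40 log units; beyond the scatter); a 3.2-fold higher number from compound 2 to compound 4 (0.50 log units; beyond the scatter); a 3.2-fold higher number from compound 1 to compound 4 (0.50 log units; beyond the scatter)), which none of the changes among compounds 1, 2 and 3 did. The closest comparison keeps the same counts of hydrogen-bond donors and acceptors and the four-membered ring with its hetero atom, while a six-membered ring replaces the other four-membered ring and the heavy-atom count rises. No measurement here explains this shift.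

With only this one compound on the higher side, the shown data cannot separate the effect of overall group size from that of this particular ring arrangement. A simple piperidine or a 4-(dimethylamino)piperidine at this position would bear on that question.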